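This account rests on a few compounds, and the source may have more. Where it says the series, first, only, none or still open, it means among the compounds named here.

Measured compounds:
compound 1 `Fc1cccc(F)c1CSc1nnc(-c2ccncc2)n1-c1ccccc1`: > 50000 nM
compound 2 `COc1ccc(/C=N/NC(=O)CSc2nnc(-c3ccncc3)n2-c2ccccc2)cc1`: 23700 nM

Of the compounds shown here, two share a core and have been tested in a functional assay on MCF7 cells (Homo sapiens) for inhibition, read by MTT assay, with a stated time of 48 h; on this read-out lower numbers stand for stronger inhibition and higher numbers for weaker inhibition. Compound 1 gives only a limit in this assay, > 50000 nM, and not a number. Among the compounds with values here, compound 2 gives 23700 nM in this assay, which is the only number in the set. The other value shown, that of compound 1, is a limit, as stated in the limit of > 50000 nM in this assay, at which 1 of the 2 values shown sits. Compound 2 thus stands alone as the sole measured point, with nothing to rank it against.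

Compound 3 `O=C(CSc1nnc(-c2ccncc2)n1-c1ccccc1)N/N=C/c1ccccc1O` has not been measured. It differs from compound 2 in one place: 2-hydroxyphenyl in place of 4-methoxyphenyl on a carbon with a double bond to nitrogen. The change swaps one oxygen-bearing group on the aromatic ring for another, adding a hydrogen-bond donor. Within the data shown here, no measured pair shows what such a swap does to the read-out, so no size of step can be drawn from the data. The step from compound 2 to compound 3 is expected to be small, a 1.3-fold lower number from compound 2 to compound 3 (0.12 log units; within the scatter), and within the usual scatter. Compound 3 is accordingly expected to give about 18000 nM in this assay, plausibly between 6000 nM and 50000 nM.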

Compound 3, half-maximal inhibitory concentration: 10000 nM
Compound 3: middle estimate off by 1.8-fold (0.26 log units), on the high side; the measured number falls inside the stated range.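

Within the data shown here, the swap of 4-methoxyphenyl for 2-hydroxyphenyl, on a carbon with a double bond to nitrogen, provides the first step that can be read in this assay: a 2.4-fold lower number from compound 2 to compound 3 (0.37 log units; beyond the scatter). This shows that the aromatic group at this place can move the number by a modest amount beyond the scatter, with the entering group bringing a hydrogen-bond donor that the leaving group lacks, although the step alone does not tie the change to that donor. Compound 1 still gives only a limit and not a number, so it adds no second step to set beside this one: the limit of > 50000 nM in this assay, at which 1 of the 3 values shown sits.

The step changes the oxygen-bearing group and its place on the ring at once, so the compounds shown leave open whether the hydroxy group or its place matters, which 4-hydroxyphenyl or 2-methoxyphenyl at the same carbon could separate. Also open, on these data alone, is how this assay would respond to a ring carrying an amine or a carboxylic acid, or to a longer chain between the sulfur and the carbonyl.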